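A few compounds are considered here, and "the series" means these few. Any claim that something is new, unique, unknown or untested is made for them only; others in the source may bear on it.

Measured compounds:
- compound 1, `COc1ccc(C2=NNC(c3ccco3)C2)cc1OC`: 45%
- compound 2, `COc1ccc(C2=NNC(c3c(Cl)cccc3Cl)C2)cc1OC`: 26%

Of the compounds shown here, two sharing one core have been measured in a functional assay on the whole organism (strain albino) for inhibition, with Rattus norvegicus as the target, read by paw edema, with stated times of 30 min and 1 h, at a dose of 100 mg/kg by the oral route; on this read-out higher numbers stand for more inhibition at the one dose given (going by the name of the read-out) and lower numbers for less inhibition. Compound 1 `COc1ccc(C2=NNC(c3ccco3)C2)cc1OC` carries a furan ring on the core and gives 45% in this assay. Compound 2 `COc1ccc(C2=NNC(c3c(Cl)cccc3Cl)C2)cc1OC` carries a dichlorophenyl ring in the same position and gives 26%. Compound 2 thus stands lowest of the two numbers, with compound 1 the nearest and higher by a gap that lies beyond the usual scatter of repeated measurements.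

Compound 3 `COc1ccc(C2=NNC(c3c(Cl)cccc3Cl)C2)cc1` has not been measured. It differs from compound 2 in one place: hydrogen in place of methoxy on an aromatic carbon. No step of this kind has been measured among the compounds shown, so nothing in the numbers points to a direction. The change is small in size, and the account therefore expects a step from compound 2 to compound 3 of a number 2 percentage points lower from compound 2 to compound 3 (within the scatter), which is not expected to go beyond the scatter in either direction. Compound 3 is accordingly estimated at 24% in this assay, with a range from 10% to 40%.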

Compound 3, a percentage reported as inhibition, in the whole organism at one dose (the size of the read-out at that dose, not a potency): 54%
Compound 3: the middle estimate sits 30 percentage points below what was measured, outside the stated range (above it).
By their numbers in this assay, from the lowest: compound 2; then compounds 1 and 3 (each within the scatter of the next).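

The step at this place shows that, in this assay, hydrogen in place of methoxy on an aromatic carbon of the six-membered aromatic ring is far from a neutral change: it gives a number 28 percentage points higher from compound 2 to compound 3 (beyond the scatter). Compound 1 and compound 2 both carry the methoxy at this place, ortho to a methoxy group, so they could say nothing about it, whereas this step shows that the read-out at this one dose responds to a change at this position, and that removing the group raises the number rather than lowering it. Nothing measured here accounts for the direction or size of this step.

Still open, on these data alone, is whether the same change would raise the number on the core of compound 1, with its furan ring, and what would happen if the methoxy that remains in compound 3 were also replaced by hydrogen. The compounds shown also leave open how a hydroxyl, a fluorine or an ethoxy would read at this place, and whether the step would hold at another dose.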